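Methoxy to hydroxy on the 2-methoxyphenyl of compound 2

The compounds below may be only part of what the source reports. "The series", "measured", "known", "first", "only" and "open" are said of these compounds alone.

Of the compounds shown here, two have been measured in a functional assay on ECa-109 cells (Homo sapiens) for inhibition, read by MTT assay, with a stated time of 72 h; a higher number here means a weaker inhibitor, a lower number a stronger inhibitor. Compound 1 `Cc1ccc(Nc2nc(SCc3cn(CC(=O)NC(=O)Nc4ccccn4)nn3)nc(-c3ccc(C(C)C)cc3)c2C#N)cc1` gives 6700 nM. Compound 2 `COc1ccccc1Nc1nc(SCc2cn(CC(=O)NC(=O)Nc3ccccn3)nn2)nc(-c2ccc(C(C)C)cc2)c1C#N`, which carries 2-methoxyphenyl in place of 4-methylphenyl on a nitrogen on an aromatic ring, gives 8960 nM; the step of a 1.3-fold higher number from compound 1 to compound 2 (0.13 log units; within the scatter) is within the scatter, so compound 2 holds the higher of the two numbers without being separable from compound 1.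

Compound 3 `CC(C)c1ccc(-c2nc(SCc3cn(CC(=O)NC(=O)Nc4ccccn4)nn3)nc(Nc3ccccc3O)c2C#N)cc1` differs from compound 2 by hydrogen in place of methyl on an oxygen on an aromatic ring, that is methoxy to hydroxy, or (2-methoxyphenyl)amino to (2-hydroxyphenyl)amino. For the measured compounds named here, no measured step touches this oxygen; the only step available, a 1.3-fold higher number from compound 1 to compound 2 (0.13 log units; within the scatter), alters a different part of the same group and stays within the scatter. The series therefore offers no ground for a step beyond the scatter in this assay in either direction, and the expectation for compound 3 is a number close to that of compound 2.

Compound 3 is accordingly estimated at 7500 nM in this assay, with a range from 3000 nM to 20000 nM. The expected step of a 1.2-fold lower number from compound 2 to compound 3 (0.08 log units; within the scatter) lies within the scatter.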

Compound 3, half-maximal inhibitory concentration: 7380 nM
Compound 3: middle estimate off by 1.0-fold (0.01 log units), on the high side, and the stated range covers the measured number.
By their numbers in this assay, from the lowest: compounds 1, 3 and 2 (each within the scatter of the next).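

In this assay, for the compounds shown here, the exchange of methoxy for hydroxy is read as a 1.2-fold lower number from compound 2 to compound 3 (0.08 log units; within the scatter) and is the first step to touch this oxygen, and it does not separate the two groups. Set against 4-methylphenyl on the same nitrogen, 2-hydroxyphenyl is read as a 1.1-fold higher number from compound 1 to compound 3 (0.04 log units; within the scatter) and so also stays unseparated, which leaves the aryl groups of compounds 1, 2 and 3 all within the scatter of one another in this assay. Nothing at hand accounts for this result.

Open, going by these compounds, is whether an amine or a carboxylic acid in place of the hydroxy, or a longer chain such as ethoxy on the same oxygen, would give a step beyond the scatter. On these data alone, compounds 1, 2 and 3 also share the same core and the same remaining groups, so it is open whether the exchange of methoxy for hydroxy would read the same once another part of the molecule is changed.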